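From Nitro to Trifluoromethyl on a Shared Core

The compounds below may be only part of what the source reports. "The series", "measured", "known", "first", "only" and "open" are said of these compounds alone.

compound 1 `COc1cc(OC)c(C(=O)/C=C/c2ccc(O)cc2)c(OC)c1`: 37000 nM
compound 2 `COc1cc(OC)c(C(=O)/C=C/c2ccccc2OC)c(OC)c1`: 16300 nM
compound 3 `COc1cc(OC)c(C(=O)/C=C/c2ccc([N+](=O)[O-])cc2)c(OC)c1`: 9400 nM

These values come from a functional assay on HepG2 cells (Homo sapiens) for inhibition, read by MTT assay, with a stated time of 72 h; on this read-out higher numbers stand for weaker inhibition and lower numbers for stronger inhibition. There, compound 3 at 9400 nM cannot be separated from compound 2, since their values lie within the usual scatter. Compound 3 stands clearly lower than compound 1, with a 3.9-fold lower number from compound 1 to compound 3 (0.60 log units; beyond the scatter).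

Compound 4 `COc1cc(OC)c(C(=O)/C=C/c2ccc(C(F)(F)F)cc2)c(OC)c1` carries trifluoromethyl in place of nitro on an aromatic carbon.

Two measured steps offer guidance, and both were modest. Nitro in place of hydroxy gave a 3.9-fold lower number from compound 1 to compound 3 (0.60 log units; beyond the scatter), while 2-methoxyphenyl in place of 4-hydroxyphenyl gave a 2.3-fold lower number from compound 1 to compound 2 (0.36 log units; beyond the scatter). Going by the values given here, both steps start from the hydroxy group of compound 1, which plays no part in the new change, and no measured compound contains trifluoromethyl. The guidance is therefore indirect, and no step beyond the scatter is expected in this assay. The expected step is a 1.0-fold lower number from compound 3 to compound 4 (0.02 log units; within the scatter). Compound 4 is estimated at 9000 nM, within an expected range of 4000 nM to 20000 nM.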

Compound 4, half-maximal inhibitory concentration: 9700 nM
Compound 4: middle estimate off by 1.1-fold (0.03 log units), on the low side; low and high end bracket the measured number.
By their numbers in this assay, from the lowest: compounds 3, 4 and 2 (each within the scatter of the next); then compound 1.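

In this assay trifluoromethyl in place of nitro, para to a large group, gives a 1.0-fold higher number from compound 3 to compound 4 (0.01 log units; within the scatter) even though the two groups share no atoms and the count of hydrogen-bond acceptors at this place falls from 2 to 0. Going by these compounds alone, the read-out therefore does not tell these two groups apart here, which the earlier compounds could not show. Within the data shown here, there is also a 3.8-fold lower number from compound 1 to compound 4 (0.58 log units; beyond the scatter) when trifluoromethyl replaces hydroxy, so nitro is no longer the only group at this place that stands clearly lower than hydroxy.

Nothing available here explains why nitro and trifluoromethyl read alike. On these data alone, whether an amine, a carboxylic acid or a longer chain at this same place would match these two groups, or fall nearer to hydroxy, stays open.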